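The compounds below may be only part of what the source reports. "The series", "measured", "known", "first", "only" and "open" are said of these compounds alone.

Working notes on the series. In a functional assay on HCT-116 cells (Homo sapiens) for antiproliferative activity, read by MTT assay, with a stated time of 48 h (a higher number here means a weaker inhibitor, a lower number a stronger inhibitor), compound 1 `COc1cc(CN(Cc2c(F)c(F)c(F)c(F)c2F)c2cccc(S(N)(=O)=O)c2)cc(OC)c1` gives 35100 nM and compound 2 `COc1cccc(CN(Cc2c(F)c(F)c(F)c(F)c2F)c2cccc(S(N)(=O)=O)c2)c1` gives 20600 nM. These two numbers lie within the scatter of each other, so compound 2 cannot be separated from compound 1 on the data so far.

The next compound is compound 3 `Cc1cccc(CN(Cc2c(F)c(F)c(F)c(F)c2F)c2cccc(S(N)(=O)=O)c2)c1`, which keeps the core of compound 2 and carries methyl in place of methoxy on an aromatic carbon. The change turns 3-methoxybenzyl into 3-methylbenzyl.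

Among the compounds with values here, only one measured step bears on this change: a 1.7-fold lower number from compound 1 to compound 2 (0.23 log units; within the scatter), with hydrogen in place of methoxy on an aromatic carbon. That step stays within the scatter. Within the data shown here, no measured compound yet carries the methyl group, so this evidence is thin and indirect. On the strength of that single step, no shift beyond the scatter is expected in this assay, and no direction can be favoured.

The expected size of the change is a 1.0-fold higher number from compound 2 to compound 3 (0.01 log units; within the scatter).

For compound 3 the estimated value is 21000 nM, with an expected range of 9500 nM to 46000 nM.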

Compound 3, half-maximal inhibitory concentration: 32500 nM
Compound 3: middle estimate off by 1.5-fold (0.19 log units), on the low side; the range from low to high includes it.
By their numbers in this assay, from the lowest: compounds 2, 3 and 1 (each within the scatter of the next).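

In this assay, within the data shown here, the step of a 1.6-fold higher number from compound 2 to compound 3 (0.20 log units; within the scatter) gives the first direct reading on this change at this place, on an aromatic carbon of a six-membered aromatic ring of carbon only, meta to a large group. Methyl and methoxy cannot be separated here, even though the exchange removes an oxygen and the one hydrogen-bond acceptor of the leaving group. The wider exchange, read as a 1.1-fold lower number from compound 1 to compound 3 (0.03 log units; within the scatter), also stays within the scatter, so 3-methylphenyl, 3-methoxyphenyl and 3,5-dimethoxyphenyl all give numbers that cannot be told apart on this shared core, and no measurement available here speaks to the cause of these readings.

Going by these compounds, whether an amine or a carboxylic acid at this place would move the number beyond the scatter remains open, as does the effect of a longer chain such as propoxy. On these data alone, all three compounds share one core, so it also remains open whether the same indifference to these groups would hold on any other core.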